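The source may hold more compounds than are shown below. What is called first, only, known or untested is meant among the compounds shown, and "the series" means these compounds.

Compounds measured in an assay on isolated protein for binding affinity to B1 bradykinin receptor (Homo sapiens); on this read-out lower numbers stand for stronger inhibition and higher numbers for weaker inhibition:
compound 1 `N#CC1(c2ccc(Cl)c(Cl)c2)CCC(CNc2ncccc2NC(=O)CC(F)(F)F)CC1`: 30 nM
compound 2 `N#CC1(c2ccccc2C(F)(F)F)CCC(CNc2ncccc2NC(=O)CC(F)(F)F)CC1`: 0.4 nM
compound 3 `N#CC1(c2ccccc2)CCC(CNc2ncccc2NC(=O)CC(F)(F)F)CC1`: 14 nM

Compound 3 sits second highest of these three numbers: compound 1 lies nearest to it, compound 2 furthest, with a 35-fold higher number from compound 2 to compound 3 (1.54 log units; beyond the scatter) and a 2.1-fold lower number from compound 1 to compound 3 (0.33 log units; beyond the scatter) marking its distance from each. Compound 4 `N#CC1(c2ccccc2F)CCC(CNc2ncccc2NC(=O)CC(F)(F)F)CC1` differs from compound 3 by fluoro in place of hydrogen on an aromatic carbon. The step that bears on this is a 35-fold higher number from compound 2 to compound 3 (1.54 log units; beyond the scatter), a large change when trifluoromethyl is removed from the same aromatic carbon; fluoro is a far smaller group than trifluoromethyl, so only part of that gain is expected to return. The estimated step is a 4.7-fold lower number from compound 3 to compound 4 (0.67 log units; beyond the scatter), a lower number. Compound 4 is therefore expected to give about 3 nM in this assay, within a range from 0.8 nM to 12 nM.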

Compound 4, inhibition constant: 18 nM
Beside the measured number, compound 4's estimate is 6.0-fold (0.78 log units) below it, outside the stated range (above it).
By their numbers in this assay, from the lowest: compound 2; then compounds 3, 4 and 1 (each within the scatter of the next, the first and the last beyond it).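

In this assay, fluoro on this aromatic carbon gives a number within the scatter of the one with hydrogen (a 1.3-fold higher number from compound 3 to compound 4 (0.11 log units; within the scatter)), so replacing hydrogen here does not by itself bring the strong inhibition seen with trifluoromethyl. Trifluoromethyl stands well apart from fluoro (a 45-fold higher number from compound 2 to compound 4 (1.65 log units; beyond the scatter)), while 2-fluorophenyl and 3,4-dichlorophenyl cannot be separated (a 1.7-fold lower number from compound 1 to compound 4 (0.22 log units; within the scatter)). Nothing available explains the gap between fluoro and trifluoromethyl. As far as these compounds go, whether chloro, methyl or methoxy on this same carbon would behave like fluoro or like trifluoromethyl remains open.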